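Double-bond geometry and cell growth inhibition

The source may hold more compounds than are shown below. What is called first, only, known or untested is meant among the compounds shown, and "the series" means these compounds.

Compound 2 `COc1cc(/C=C\c2ccc(N3CCNC3=O)cc2)cc(OC)c1OC` gives the lowest number of the three measured in a functional assay on MCF7 cells (Homo sapiens) for inhibition, read by sulforhodamine B assay, with a stated time of 48 h (a lower number here means a stronger inhibitor, a higher number a weaker inhibitor), where compound 2 gives 2.6 nM. Compound 3 `O=C1NCCN1c1ccc(/C=C\c2cccc(Cl)c2)cc1` follows, and in this assay compound 3 gives 38 nM, while compound 1 `O=C1NCCN1c1ccc(/C=C/c2cccc(Cl)c2)cc1` is the weakest, since in this assay compound 1 gives 20000 nM. Within the data shown here, compound 4 `COc1cc(/C=C/c2ccc(N3CCNC3=O)cc2)cc(OC)c1OC` is not yet measured. the two compounds have the same atoms and bonds and differ only in configuration as drawn: 1 of 1 stereo elements differ; a double bond is drawn Z in compound 2 and E in compound 4 The one measured step that bears on this change is a 530-fold lower number from compound 1 to compound 3 (2.72 log units; beyond the scatter), which rests on the fact that compounds 1 and 3 differ only in the configuration as drawn and runs in the opposite direction. The same change, run from drawn Z to drawn E, is therefore expected to raise the number by a large amount, estimated as a 500-fold higher number from compound 2 to compound 4 (2.70 log units; beyond the scatter). Compound 4 is thus expected to give about 1300 nM in this assay, within a range of 200 nM to 10000 nM.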

Compound 4, half-maximal inhibitory concentration: 540 nM
Compound 4: middle estimate off by 2.4-fold (0.38 log units), on the high side, and the stated range covers the measured number.
By their numbers in this assay, from the lowest: compound 2; then compound 3; then compound 4; then compound 1.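

In this assay the change from drawn Z to drawn E gives a 210-fold higher number from compound 2 to compound 4 (2.32 log units; beyond the scatter), so the drawn E form again carries the higher number, now in a pair bearing methoxy groups instead of chlorine. The earlier compounds shown here showed this only for the chlorine-bearing pair; the two pairs now agree, and neither goes against it. The step can rest on geometry alone: the fact that compounds 2 and 4 differ only in the configuration as drawn.

The compounds shown leave open whether the same holds with a hydroxyl group or an amine in place of the methoxy groups or the chlorine.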